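Methoxy to hydroxy on compound 1

The source may report more compounds than this note shows. Statements on the series, on what has been measured and on what is new or still open speak of the compounds shown alone.

In a functional assay on HaCaT cells (Homo sapiens) for cytotoxicity, with a stated time of 48 h (on this read-out lower numbers stand for stronger inhibition and higher numbers for weaker inhibition), compound 1 (`COc1cc(OC)c(C(=O)/C=C/c2ccccc2SC)c(OC)c1`) gives 7700 nM and compound 2 (`COc1cc(OC)c(C(=O)/C=C/c2ccc(Cl)cc2)c(OC)c1`) gives 7600 nM as well, so the two stand level, their step (a 1.0-fold lower number from compound 1 to compound 2 (0.01 log units; within the scatter)) lying within the scatter. Compound 3 (`COc1cc(O)c(C(=O)/C=C/c2ccccc2SC)c(OC)c1`) differs from compound 1 by one change (hydrogen in place of methyl on an oxygen on an aromatic ring), methoxy to hydroxy: hydrogen in place of methyl on an oxygen on an aromatic ring. Among the compounds with values here, no measured step tests this change, since the only one available lies elsewhere on the molecule. The expected step (a 1.2-fold lower number from compound 1 to compound 3 (0.07 log units; within the scatter)) in this assay therefore stays within the scatter, with no direction favoured. Compound 3 is estimated at 6500 nM (range 2500 nM to 16000 nM).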

Compound 3, half-maximal inhibitory concentration: 10500 nM
Compound 3: the middle estimate sits 1.6-fold (0.21 log units) below what was measured; the range from low to high includes it.
By their numbers in this assay, from the lowest: compounds 2, 1 and 3 (each within the scatter of the next).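

Hydrogen in place of methyl on an oxygen on an aromatic ring is the first change at this place with a measured result, and in this assay it stays within the scatter (a 1.4-fold higher number from compound 1 to compound 3 (0.13 log units; within the scatter)). On compound 1, then, this methyl can be replaced by hydrogen with no clear shift in the read-out. Nothing available explains this result.

Still open, going by these compounds, is whether a larger group on this oxygen, such as an ethyl or a longer chain carrying an amine, would also stay within the scatter. Also open, on these data alone, is whether methoxy to hydroxy gives a similar result on compound 2.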